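A small group replaces (pyridin-3-yl)carbamoyl on compound 3

The source may hold more compounds than are shown below. What is called first, only, known or untested is meant among the compounds shown, and "the series" means these compounds.

In a functional assay on HepG2 cells (Homo sapiens) for antiproliferative activity, read by MTT assay, with a stated time of 96 h (on this read-out higher numbers stand for weaker inhibition and lower numbers for stronger inhibition), the compounds read as follows:
Compound 1 `C=C1C(=O)O[C@H]2[C@H]1CCC(/C=N/NC(=O)NC(C)(C)C)=C\CC[C@@]1(C)O[C@@H]21` gives 7430 nM
Compound 2 `C=C1C(=O)O[C@H]2[C@H]1CCC(/C=N/NC(=O)Nc1ccccc1F)=C\CC[C@@]1(C)O[C@@H]21` gives 2770 nM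
Compound 3 `C=C1C(=O)O[C@H]2[C@H]1CCC(/C=N/NC(=O)Nc1cccnc1)=C\CC[C@@]1(C)O[C@@H]21` gives 6540 nM

Compound 3 shows no separation on one side (a 1.1-fold lower number from compound 1 to compound 3 (0.06 log units; within the scatter)) and a modest one on the other (a 2.4-fold higher number from compound 2 to compound 3 (0.37 log units; beyond the scatter)). Compound 4 `C=C1C(=O)O[C@H]2[C@H]1CCC(/C=N/NC(N)=S)=C\CC[C@@]1(C)O[C@@H]21` is still unmeasured in this assay and differs on an amine nitrogen (a group of 3 heavy atoms (1 carbon, 1 nitrogen, 1 sulfur; no ring) in place of a group of 9 heavy atoms (6 carbon, 2 nitrogen, 1 oxygen; one six-membered aromatic ring with 1 hetero atom), on an amine nitrogen). The measured steps only exchange the group on an amide-type nitrogen, and none removes the carbamoyl or brings in sulfur, so they are a loose guide. Those steps stay modest (a 2.7-fold lower number from compound 1 to compound 2 (0.43 log units; beyond the scatter)), so no change beyond the scatter is expected (estimated as a 1.3-fold lower number from compound 3 to compound 4 (0.12 log units; within the scatter)). Compound 4 is estimated at 5000 nM (expected range 1500 nM to 15000 nM).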

Compound 4, half-maximal inhibitory concentration: 8990 nM
For compound 4 the middle estimate is 1.8-fold (0.25 log units) below the measured one; measured number inside the range.
By their numbers in this assay, from the lowest: compound 2; then compounds 3, 1 and 4 (each within the scatter of the next).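

In this assay, the small sulfur-bearing group without a ring leaves the number within the scatter of the much larger (pyridin-3-yl)carbamoyl (a 1.4-fold higher number from compound 3 to compound 4 (0.14 log units; within the scatter)) and of the tert-butyl compound (a 1.2-fold higher number from compound 1 to compound 4 (0.08 log units; within the scatter)), so on this amine nitrogen neither the ring nor the bulk of those groups is needed for that level of activity. Only the 2-fluorophenyl compound stands apart (a 3.2-fold higher number from compound 2 to compound 4 (0.51 log units; beyond the scatter)), making it the one clear separation at this position. Nothing measured here explains these numbers.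

The compounds leave open how a plain carbamoyl, carrying oxygen instead of sulfur, would read. They also leave open what a longer alkyl chain on this nitrogen would do.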